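The compounds below may be only part of what the source reports. "The series", "measured", "known", "first", "only" and "open" are said of these compounds alone.

Measured so far:
compound 1, `CC(C)(C)N(NC(=O)c1ccccc1)C(=O)c1ccccc1F`, which in an assay on cells for agonist activity at ecdysone receptor (Bombyx mori), read by a luciferase reporter, with a stated time of 24 h (a higher number here means that more compound is needed for the effect, a lower number that less compound is needed), gives 309 nM;
compound 2, `CCc1ccccc1C(=O)N(NC(=O)c1ccccc1)C(C)(C)C`, which in this assay gives 589 nM.

Compound 2 holds the higher of the two numbers, with compound 1 nearest; the step of a 1.9-fold higher number from compound 1 to compound 2 (0.28 log units; within the scatter) lies within the scatter, so the two are not separated.

Compound 3, `CC(C)(C)N(NC(=O)c1ccccc1)C(=O)C1CCCCC1`, differs from compound 2 by cyclohexyl in place of 2-ethylphenyl on a carbonyl carbon. Within the data shown here, the single measured step, a 1.9-fold higher number from compound 1 to compound 2 (0.28 log units; within the scatter), concerns a substituent on an aromatic carbon and does not bear on exchanging the whole 2-ethylphenyl for cyclohexyl on the carbonyl carbon; no measured pair covers such a change. Among the measured compounds shown here, the expectation therefore rests on no direct precedent and is held loosely: the number for compound 3 is expected to move upward by a 3.1-fold higher number from compound 2 to compound 3 (0.49 log units; beyond the scatter), a step beyond the scatter. Compound 3 is estimated at 1800 nM, within 400 nM to 8000 nM.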

Compound 3, half-maximal effective concentration: 46800 nM
The estimate for compound 3 lay 26-fold (1.41 log units) below the measured number; measured number outside the range, above it.
By their numbers in this assay, from the lowest: compounds 1 and 2 (each within the scatter of the next); then compound 3.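

Among these compounds, on the carbonyl carbon, the aromatic ring is the first feature whose exchange reads clearly in this assay: cyclohexyl in place of 2-ethylphenyl gives a 79-fold higher number from compound 2 to compound 3 (1.90 log units; beyond the scatter), and cyclohexyl in place of 2-fluorophenyl gives a 150-fold higher number from compound 1 to compound 3 (2.18 log units; beyond the scatter). Both steps are large, whereas fluoro and ethyl on the aromatic carbon stay unseparated, so among these compounds the choice of ring at this place outweighs the choice of that substituent. Nothing measured here accounts for the size of these steps.

On these data alone, each step removes the ring and its substituent together, so a plain phenyl on the carbonyl carbon remains open as the comparison that would separate the two. Also open, as far as these compounds go, is how a methoxy group, an amine or a chain longer than ethyl reads on the aromatic carbon.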